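Ethoxy in Place of Isopropoxy on an Oxadiazole Series

A few compounds are considered here, and "the series" means these few. Any claim that something is new, unique, unknown or untested is made for them only; others in the source may bear on it.

The account concerns four compounds built on a shared core. Compound 1 `Cc1ccccc1-c1noc(-c2ccc(C3CCCCC3)cc2)n1` carries a methyl on one aryl ring and a cyclohexyl on the other. In a functional assay on CHO cells with sphingosine 1-phosphate receptor 2 (Homo sapiens) as the target, read by GTPgammaS binding (on this read-out higher numbers stand for an effect only at larger amounts of compound and lower numbers for an effect already at smaller amounts), compound 1 gives only a limit of > 10000 nM. Compound 2 `Cc1cc(C(=O)O)ccc1-c1noc(-c2ccc(C3CCCCC3)cc2)n1` adds a carboxy on an aromatic carbon; in this assay compound 2 likewise gives only a limit of > 10000 nM. The step that the two limits leave unreadable from compound 1 to compound 2 is therefore not readable. Compound 3 `Cc1cc(CCC(=O)O)ccc1-c1noc(-c2ccc(OC(C)C)c(C(F)(F)F)c2)n1` carries a propanoic acid chain and an isopropoxy with a trifluoromethyl; in this assay compound 3 also gives only a limit of > 10000 nM. Within the data shown here, all three values sit at the limit of > 10000 nM in this assay, at which 3 of the 3 values shown sit, so compound 3 stands at the limit together with the others, and no measured step gives a readable size.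

Compound 4 `CCOc1ccc(-c2nc(-c3ccc(CCC(=O)O)cc3C)no2)cc1C(F)(F)F` differs from compound 3 by hydrogen in place of methyl on a saturated chain carbon bound to an oxygen on an aromatic ring and a saturated chain carbon. With no readable step to lean on, the expectation for compound 4 in this assay is that it again sits near the limit, estimated at 15000 nM with a range of 4000 nM to 60000 nM, so that the expected step that the limit leaves unreadable from compound 3 to compound 4 is none beyond the scatter.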

Compound 4, half-maximal effective concentration: > 10000 nM
Compound 4: only a limit was reported (the forecaster's own chance of this, stated with the estimate: 85%); the middle value does not contradict the limit.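

No step can be read from compound 3 to compound 4, as each gives only a limit in this assay and the isopropoxy to ethoxy change therefore has no readable size. The compounds shown leave open whether any of the four has a measurable effect in this assay at all.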